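The source may report more compounds than this note shows. Statements on the series, on what has been measured and on what is new or still open speak of the compounds shown alone.

Compound 1 `COc1cc(C(c2ccc(O)c(OC)c2)[C@@H](C)[C@H](C)CO)ccc1O`: in a functional assay on HeLa cells (Homo sapiens) for cytotoxicity, read by WST assay, with a stated time of 48 h (a lower number here means a stronger inhibitor, a higher number a weaker inhibitor), compound 1 gives > 100000 nM, a limit of the assay rather than a number.
Compound 2 `COc1cc(C(c2ccc(O)c(OC)c2)[C@H](C)[C@H](C)CF)ccc1O`: in this assay compound 2 gives 75000 nM.
Compound 3 `COc1ccc(C(c2ccc(OC)c(OC)c2)[C@H](C)[C@@H](C)CO)cc1OC`: in this assay compound 3 gives 67000 nM.

Within the data shown here, compound 2 and compound 3 give the only two numbers here, and they lie within the scatter of each other; compound 1 sits at the limit (the limit of > 100000 nM in this assay, at which 1 of the 3 values shown sits). Among the measured compounds shown here, the one measured step, an at least 1.3-fold lower number from compound 1 to compound 2 (0.12 log units; that floor lies within the scatter), is itself bounded by that limit and so reads only as a floor within the scatter. Compound 4 `COc1cc(C(c2ccc(O)c(OC)c2)[C@H](C)C(C)C)ccc1O` differs from compound 2 by hydrogen in place of fluoro on a saturated chain carbon, four bonds along the chain from two aromatic carbons. Nothing measured here separates such a change from the scatter, so for compound 4 no step beyond the scatter is expected in this assay, that is no change at the digits printed from compound 2 to compound 4 (within the scatter). Compound 4 is estimated at 75000 nM, between 35000 nM and 160000 nM.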

Compound 4, half-maximal inhibitory concentration: 16000 nM
For compound 4 the middle estimate is 4.7-fold (0.67 log units) above the measured one, and the stated range ends above it.
By their numbers in this assay, from the lowest: compound 4; then compounds 3 and 2 (each within the scatter of the next). At a limit, above all of these: compound 1.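

In this assay, among these compounds, the chain end now shows a step beyond the scatter, which the earlier compounds did not: a 4.7-fold lower number from compound 2 to compound 4 (0.67 log units; beyond the scatter). The 1,2-dimethylpropyl of compound 4 also stands apart from the 2-(hydroxymethyl)-1-methylpropyl of compound 1, with an at least 6.2-fold lower number from compound 1 to compound 4 (0.79 log units; beyond the scatter). That step is only a floor, set by the limit reached by compound 1: the limit of > 100000 nM in this assay, at which 1 of the 4 values shown sits.

The compounds shown leave open how an amine, a carboxylic acid or a longer chain at this place would read in this assay.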